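Amide group changes at the carbonyl carbon

A few compounds are considered here, and "the series" means these few. Any claim that something is new, unique, unknown or untested is made for them only; others in the source may bear on it.

Compound 1 `CN1[C@@H]2c3[nH]c4ccccc4c3C[C@H]1[C@H](C#N)N1[C@@H](CNC(=O)c3ccc(Cl)cc3)c3[nH]c4ccccc4c3C[C@@H]21` is the reference. In a functional assay on A2780 cells (Homo sapiens) for cytotoxicity, read by MTT assay, with a stated time of 72 h (on this read-out higher numbers stand for weaker inhibition and lower numbers for stronger inhibition), compound 1 gives 230 nM, the lowest of the two numbers in hand. Compound 2 `CN1[C@@H]2c3[nH]c4ccccc4c3C[C@H]1[C@H](C#N)N1[C@@H](CNC(=O)c3ccc4ccccc4c3)c3[nH]c4ccccc4c3C[C@@H]21` carries naphthalen-2-yl in place of 4-chlorophenyl on the carbonyl carbon; in this assay compound 2 gives 1030 nM. Compound 3 `CN1[C@@H]2c3[nH]c4ccccc4c3C[C@H]1[C@H](C#N)N1[C@@H](CNC(=O)/C=C/c3ccccc3)c3[nH]c4ccccc4c3C[C@@H]21` is not yet measured and differs from compound 1 as follows: 2-phenylethenyl in place of 4-chlorophenyl on a carbonyl carbon. Going by the values given here, the only measured guide is the step of a 4.5-fold higher number from compound 1 to compound 2 (0.65 log units; beyond the scatter), which likewise exchanges the group on the carbonyl carbon for one with more heavy atoms and went beyond the scatter. The entering 2-phenylethenyl also adds heavy atoms relative to 4-chlorophenyl, so a rise in this assay is expected, though probably smaller than for compound 2, since nothing measured separates the two new groups. Compound 3 is estimated at 450 nM (range 180 nM to 1200 nM), an expected step of a 2.0-fold higher number from compound 1 to compound 3 (0.29 log units; within the scatter).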

Compound 3, half-maximal inhibitory concentration: 770 nM
The estimate for compound 3 lay 1.7-fold (0.23 log units) below the measured number; measured number inside the range.
By their numbers in this assay, from the lowest: compound 1; then compounds 3 and 2 (each within the scatter of the next).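

Replacing 4-chlorophenyl on the carbonyl carbon with a second, different group also gives a higher number in this assay (a 3.3-fold higher number from compound 1 to compound 3 (0.52 log units; beyond the scatter)), so compound 1 remains the lowest of the three. The loss therefore does not depend on naphthalen-2-yl, and exchanging that group for 2-phenylethenyl leaves the two entering groups unseparated (a 1.3-fold lower number from compound 2 to compound 3 (0.13 log units; within the scatter)). Nothing available gives a reason for the rise at this position.

On these data alone, neither compound 2 nor compound 3 carries chlorine, so it remains open whether the lower number of compound 1 is tied to the chlorine or to the directly attached phenyl ring. Plain phenyl, 4-fluorophenyl or 4-methoxyphenyl on the carbonyl carbon would address this, and cyclohexyl would test whether an aromatic ring is needed there at all.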